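This account rests on a few compounds, and the source may have more. Where it says the series, first, only, none or still open, it means among the compounds named here.

In a functional assay on MCF7 cells (Homo sapiens) for cytotoxicity (a higher number here means a weaker inhibitor, a lower number a stronger inhibitor), compound 1 `Nc1ccc(-c2nc3c(O)cccc3s2)cc1Cl` gives 61400 nM and compound 2 `CC(=O)Nc1ccc(-c2nc3c(O)cccc3s2)cc1C` gives 33000 nM, two values within the scatter of each other. Compound 3 `Cc1cc(-c2nc3c(O)cccc3s2)ccc1N` reaches only a limit of the assay, > 100000 nM. Compound 4 `CC(=O)Nc1ccc(-c2nc3c(O)cccc3s2)cc1Cl` differs from compound 2 by chloro in place of methyl on an aromatic carbon, with chloro in place of methyl on an aromatic carbon, ortho to an acetamido group. The reverse exchange, methyl in place of chloro, gave an at least 1.6-fold higher number from compound 1 to compound 3 (0.21 log units; that floor lies within the scatter). Hydrogen in place of acetyl gave an at least 3.0-fold higher number from compound 2 to compound 3 (0.48 log units; beyond the scatter), so the acetyl group stays in both compounds of the new pair. In this assay, a slightly lower number is therefore expected, with no step beyond the scatter. The expected change is a 1.3-fold lower number from compound 2 to compound 4 (0.12 log units; within the scatter). Compound 4 is estimated at 25000 nM, within an expected range of 9000 nM to 70000 nM.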

Compound 4, half-maximal inhibitory concentration: 56800 nM
Estimate against measurement, compound 4: 2.3-fold (0.36 log units) below, and the stated range covers the measured number.
By their numbers in this assay, from the lowest: compounds 2, 4 and 1 (each within the scatter of the next). At a limit, above all of these: compound 3.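

In this assay, with the acetamido group present, the exchange at this position gives a 1.7-fold higher number from compound 2 to compound 4 (0.24 log units; within the scatter), so methyl and chloro are not told apart here. With chloro in place, acetyl on the nitrogen gives a 1.1-fold lower number from compound 1 to compound 4 (0.03 log units; within the scatter), so the lower number that acetyl brought with methyl in place does not recur: the same change on two cores in this assay, an at least 3.0-fold higher number (0.48 log units; beyond the scatter) from compound 2 to compound 3 and a 1.1-fold higher number (0.03 log units; within the scatter) from compound 4 to compound 1, at least 2.8-fold (0.44 log units) apart, beyond the scatter of two such steps The exchange of methyl and chloro likewise differs between the free amine and the acetamido compounds: the same change on two cores in this assay, an at least 1.6-fold higher number (0.21 log units; that floor lies within the scatter) from compound 1 to compound 3 and a 1.7-fold lower number (0.24 log units; within the scatter) from compound 4 to compound 2, at least 2.8-fold (0.44 log units) apart, beyond the scatter of two such steps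

Still open, from the compounds shown here alone, is whether fluoro or methoxy at this position, or a longer chain than acetyl on the nitrogen, would move the number beyond the scatter. The value of compound 3 is only a limit, which leaves the full size of both those gaps open: the limit of > 100000 nM in this assay, at which 1 of the 4 values shown sits.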